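Acetyl for 4-methoxybenzyl: solubility notes

The source may hold more compounds than are shown below. What is called first, only, known or untested is meant among the compounds shown, and "the series" means these compounds.

- Compound 1 `NC(=O)c1ccc2[nH]c(-c3ccc(OCC4CCCN(Cc5ccccc5)C4)cc3)nc2c1` gives > 400000 nM as a limit
- Compound 2 `COc1ccc(CN2CCCCC2CCOc2ccc(-c3nc4cc(C(N)=O)ccc4[nH]3)cc2)cc1` gives > 400000 nM as a limit

In a physicochemical assay for solubility, with a stated time of 3 days, at pH 2 (a lower number here means a less soluble compound, a higher number a more soluble compound), compound 2 stands at > 400000 nM as a limit, not a number. For the measured compounds named here, the series so far shows the limit of > 400000 nM in this assay, at which 2 of the 2 values shown sit, and nothing finer. Compound 3 `CC(=O)N1CCCCC1CCOc1ccc(-c2nc3cc(C(N)=O)ccc3[nH]2)cc1` has acetyl in place of 4-methoxybenzyl on an amine nitrogen in a ring, counted as acetyl in place of 4-methoxybenzyl on an amine nitrogen in a ring in full. Going by the values given here, no measured step exists to guide the expectation, which rests on this structural change alone. A moderate downward move is expected, read as an at least 2.0-fold lower number from compound 2 to compound 3 (0.30 log units; that floor lies within the scatter) in this assay terms. Compound 3 is estimated at 200000 nM with an expected range from 50000 nM to 400000 nM for its solubility.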

Compound 3, solubility: > 400000 nM
Compound 3: only a limit was reported (the forecaster's own chance of this, stated with the estimate: 35%); middle value at least 2.0-fold (0.30 log units) from the limit.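

No new step can be read from compound 2 to compound 3, since both results are limits: the limit of > 400000 nM in this assay, at which 3 of the 3 values shown sit.

The compounds shown leave open how compound 1, compound 2 and compound 3 rank in this assay, and whether acetyl in place of 4-methoxybenzyl changes the read-out at all.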